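Swapping the thiophene-bearing arm of compound 1

This account rests on a few compounds, and the source may have more. Where it says the series, first, only, none or still open, it means among the compounds named here.

Results in a functional assay on DU-145 cells (Homo sapiens) for inhibition, read by trypan blue exclusion, with a stated time of 96 h; a higher number here means a weaker inhibitor of growth, a lower number a stronger inhibitor of growth
- compound 1 `Cc1ccc(S(=O)(=O)/C(=C/c2sccc2C)C(=O)c2ccc(Cl)cc2)cc1` gives 10000 nM
- compound 2 `Cc1ccc(S(=O)(=O)/C(=C/c2sccc2C)C(=O)c2ccc(Br)cc2)cc1` gives 25000 nM
- compound 3 `Cc1ccsc1/C=C(\C(=O)c1ccc(Cl)cc1)S(=O)(=O)Cc1ccc(F)cc1` gives 10000 nM

Compound 1 shares the lowest number of the three with compound 3. Compound 4 `Cc1ccc(S(=O)(=O)/C(=C/c2cc(C)ccc2C)C(=O)c2ccc(Cl)cc2)cc1` carries 2,5-dimethylphenyl in place of 3-methylthiophen-2-yl on a double-bonded chain carbon bound to a double-bonded chain carbon. For the measured compounds named here, no measured step touches that place. The two nearest guides change other places: a 2.5-fold higher number from compound 1 to compound 2 (0.40 log units; beyond the scatter) and no change at the digits printed from compound 1 to compound 3 (within the scatter). Going by the values given here, they suggest only that single changes here have been small, and they give no direction. The expected step in this assay is therefore a 1.2-fold higher number from compound 1 to compound 4 (0.08 log units; within the scatter), probably not beyond the scatter. For compound 4 the estimate is 12000 nM, with an expected range of 4000 nM to 35000 nM.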

Compound 4, concentration for 50% growth inhibition: 1000 nM
Estimate against measurement, compound 4: 12-fold (1.08 log units) above; the measured number lies below the stated range.
By their numbers in this assay, from the lowest: compound 4; then compounds 1 and 3 (each within the scatter of the next); then compound 2.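

In this assay putting 2,5-dimethylphenyl in place of 3-methylthiophen-2-yl gives a 10-fold lower number from compound 1 to compound 4 (1.00 log units; beyond the scatter) and this step lies beyond the scatter. For the compounds shown here, the earlier steps all changed other places, so this is the first sign that the group on this double-bonded chain carbon can clearly shift growth inhibition. Here the six-membered aromatic ring of carbon only gives the stronger inhibitor of the pair.

Whether the ring itself or its two methyl groups account for the difference stays open, and a plain phenyl group here would help separate the two. No measurement available here explains the difference.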